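This account rests on a few compounds, and the source may have more. Where it says the series, first, only, none or still open, it means among the compounds named here.

Measured in a functional assay on A2780 cells (Homo sapiens) for inhibition, read by sulforhodamine B assay, with a stated time of 72 h; on this read-out lower numbers stand for stronger inhibition and higher numbers for weaker inhibition:
- compound 1 `O=C(NCc1ccc(S(=O)(=O)c2ccccc2)cc1)c1nc2cnccc2[nH]1`: 5400 nM
- compound 2 `O=C(NCc1ccc(S(=O)(=O)c2cccc(C(F)(F)F)c2)cc1)c1cc2cnccc2[nH]1`: 3 nM
- compound 3 `O=C(NCc1ccc(S(=O)(=O)c2ccccc2)cc1)c1cn2ccnc2cn1`: > 10000 nM

Compound 3 stands at the limit of > 10000 nM in this assay, at which 1 of the 3 values shown sits, so its value is a limit and not a number. Compound 4 `O=C(NCc1ccc(S(=O)(=O)c2ccccc2)cc1)c1cc2cnccc2[nH]1` has not yet been measured. It differs from compound 3 in one place, on a carbonyl carbon whose other neighbours are an amide-type nitrogen: a group of 9 heavy atoms (7 carbon, 2 nitrogen; one five-membered aromatic ring with 1 hetero atom, one six-membered aromatic ring with 1 hetero atom) in place of a group of 9 heavy atoms (6 carbon, 3 nitrogen; one five-membered aromatic ring with 2 hetero atoms, one six-membered aromatic ring with 2 hetero atoms), on a carbonyl carbon.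

Among the compounds with values here, the only measured step at this place is an at least 1.8-fold higher number from compound 1 to compound 3 (0.26 log units; that floor lies within the scatter). Its floor lies within the scatter, and it does not involve the group that enters here, so it says little about the size of the coming step. The better guide is compound 2, which already carries the entering group and gives 3 nM in this assay. Within the data shown here, compound 2 also has a trifluoromethyl group that compound 4 lacks, and no measured step isolates that group, so the guide is imperfect and the range must stay wide.

A large fall in the number, well beyond the scatter, is therefore expected, with an estimated at least 660-fold lower number from compound 3 to compound 4 (2.82 log units; beyond the scatter). For compound 4 the expected value is 15 nM, with an estimated range of 3 nM to 100 nM.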

Compound 4, half-maximal inhibitory concentration: 18 nM
For compound 4 the middle estimate is 1.2-fold (0.08 log units) below the measured one; low and high end bracket the measured number.
By their numbers in this assay, from the lowest: compound 2; then compound 4; then compound 1. At a limit, above all of these: compound 3.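

In this assay, the group on the carbonyl carbon decides most of what is seen, and the group with 7 carbon and 2 nitrogen atoms now proves strong without any other change to the molecule: a 300-fold lower number from compound 1 to compound 4 (2.48 log units; beyond the scatter), and an at least 550-fold lower number from compound 3 to compound 4 (2.74 log units; beyond the scatter), the latter a floor and not an exact size. Within the data shown here, compound 3 stands at a limit and not at a number: the limit of > 10000 nM in this assay, at which 1 of the 4 values shown sits. The trifluoromethyl group can also be read alone for the first time, and with hydrogen in place of trifluoromethyl on an aromatic carbon the change is only modest, a 6.0-fold higher number from compound 2 to compound 4 (0.78 log units; beyond the scatter), so in these two compounds the entering group keeps its strength without trifluoromethyl.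

The compounds shown do not tell which atom of the entering group accounts for the large steps, since the groups compared differ in their ring atoms and no pair isolates a single one. They also leave open how a chlorine atom, a methoxy group or an amine would compare with trifluoromethyl on that aromatic carbon, and whether any such group would exceed compound 2.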